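From chloro to ethyl: a small expected step

The compounds below may be only part of what the source reports. "The series", "measured", "known", "first", "only" and "open" are said of these compounds alone.

The measured compounds in a functional assay on MT2 cells (Homo sapiens) for cytotoxicity, read by MTT assay (a higher number here means that more compound is tolerated, a lower number that less compound is tolerated), are these.
- Compound 1 `CC(C)=CCOc1cc(Nc2nccs2)ccc1C` gives 17000 nM
- Compound 2 `COc1ccc(Nc2nccs2)cc1OCC=C(C)C` gives 42000 nM
- Compound 3 `CC(C)=CCOc1cc(Nc2nccs2)ccc1Cl` gives 26000 nM

Compound 3 gives 26000 nM and lies within the scatter of both other compounds. Among the compounds with values here, the only step beyond the scatter is a 2.5-fold higher number from compound 1 to compound 2 (0.39 log units; beyond the scatter) and it is modest.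

Compound 4 `CCc1ccc(Nc2nccs2)cc1OCC=C(C)C` has ethyl in place of chloro on an aromatic carbon, ortho to a (3-methylbut-2-en-1-yl)oxy group and para to a (1,3-thiazol-2-yl)amino group (ethyl in place of chloro on an aromatic carbon). Within the data shown here, no measured pair makes this exchange, and no ethyl compound has a value yet.

The closest evidence comes from changes at the same place. One is a 1.5-fold higher number from compound 1 to compound 3 (0.18 log units; within the scatter) for chloro in place of methyl. The other is a 1.6-fold lower number from compound 2 to compound 3 (0.21 log units; within the scatter) for chloro in place of methoxy. Neither exchange moves the number beyond the scatter, so no step beyond the scatter is expected in this assay here. Compound 1 with its methyl gives 17000 nM and so suggests a slight lean to a lower number for ethyl.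

The estimated change is a 1.2-fold lower number from compound 3 to compound 4 (0.09 log units; within the scatter) and would be small. For compound 4 the expected value is 21000 nM with an estimated range from 10000 nM to 42000 nM as its limits.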

Compound 4, half-maximal cytotoxic concentration: 31000 nM
For compound 4 the middle estimate is 1.5-fold (0.17 log units) below the measured one; the measured number falls inside the stated range.
By their numbers in this assay, from the lowest: compounds 1, 3, 4 and 2 (each within the scatter of the next, the first and the last beyond it).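

In this assay, ethyl at this position, ortho to a (3-methylbut-2-en-1-yl)oxy group and para to a (1,3-thiazol-2-yl)amino group, cannot be told apart from any of the three groups seen there before: replacing chloro gives a 1.2-fold higher number from compound 3 to compound 4 (0.08 log units; within the scatter), replacing methoxy gives a 1.4-fold lower number from compound 2 to compound 4 (0.13 log units; within the scatter), and growing the methyl of compound 1 into ethyl, with methyl in place of hydrogen on a saturated chain carbon bound to an aromatic carbon, gives a 1.8-fold higher number from compound 1 to compound 4 (0.26 log units; within the scatter). Within the data shown here, the one step beyond the scatter in the set remains a 2.5-fold higher number from compound 1 to compound 2 (0.39 log units; beyond the scatter), and compound 4 lies within the scatter of both of those compounds, so it sits in the gap between them and does not widen the spread. Nothing available explains why these four numbers stay so close together.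

The compounds shown leave open whether a longer chain such as propyl, an amine or a carboxylic acid at this position would stay within the same narrow spread. They also leave open whether these exchanges would read the same with the (3-methylbut-2-en-1-yl)oxy group replaced by another group.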